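A few compounds are considered here, and "the series" means these few. Any claim that something is new, unique, unknown or untested is made for them only; others in the source may bear on it.

Measured so far:
- compound 1 `O=C(O)c1ccc2c(c1)nc(-c1ccc(OCc3ccccc3-c3ccc(Cl)cc3)cc1)n2C1CCCCC1`: 25000 nM
- compound 2 `CC(=O)c1ccc(-c2ccc(Cl)cc2)c(COc2ccc(-c3nc4cc(C(=O)O)ccc4n3C3CCCCC3)cc2)c1`: 24000 nM

In a functional assay on Huh-5-2 cells (Homo sapiens), read by MTT assay (a lower number here means that less compound is tolerated, a higher number that more compound is tolerated), compound 2 gives 24000 nM, which lies within the scatter of compound 1 at 25000 nM. The two numbers therefore place neither compound ahead of the other.

The next compound is compound 3 `CN(C)c1ccc(-c2ccc(Cl)cc2)c(COc2ccc(-c3nc4cc(C(=O)O)ccc4n3C3CCCCC3)cc2)c1`, with dimethylamino in place of acetyl on an aromatic carbon, para to a 4-chlorophenyl group: dimethylamino in place of acetyl on an aromatic carbon.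

Going by the values given here, only one measured step bears on this carbon: a 1.0-fold lower number from compound 1 to compound 2 (0.02 log units; within the scatter), with acetyl in place of hydrogen. That step stays within the scatter, so replacing hydrogen with acetyl left no visible mark in this assay. Among the compounds with values here, no measured compound carries dimethylamino, so this evidence is indirect and rests on a single pair.

The expectation is therefore no change beyond the scatter and no preferred direction, with the expected move being a 1.1-fold lower number from compound 2 to compound 3 (0.04 log units; within the scatter). For compound 3 the estimated value is 22000 nM, with an expected range from 10000 nM to 50000 nM.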

Compound 3, half-maximal cytotoxic concentration: 30000 nM
The estimate for compound 3 lay 1.4-fold (0.13 log units) below the measured number, within the range that was stated.
By their numbers in this assay, from the lowest: compounds 2, 1 and 3 (each within the scatter of the next).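

In this assay, exchanging one substituent for another on this carbon, para to a 4-chlorophenyl group, gives no reading beyond the scatter (a 1.3-fold higher number from compound 2 to compound 3 (0.10 log units; within the scatter)), and neither does dimethylamino set against hydrogen (a 1.2-fold higher number from compound 1 to compound 3 (0.08 log units; within the scatter)). The position now holds hydrogen, acetyl and dimethylamino, and all three compounds sit within the scatter of one another, so the earlier single pair is joined by a second group, one with nitrogen where acetyl has oxygen and with no carbonyl, and the flat picture holds across these three compounds only. No supporting data are available to explain this flat result.

The compounds shown leave open whether a carboxylic acid, a primary amine or a longer chain on this carbon would move the number beyond the scatter. They also leave open whether the same flat picture would hold on another carbon of this six-membered aromatic ring, or with some other group in place of the 4-chlorophenyl group.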